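This account rests on a few compounds, and the source may have more. Where it says the series, first, only, none or still open, it means among the compounds named here.

Measured in a functional assay on RAW264.7 cells (Mus musculus) for inhibition, read by Griess assay, with stated times of 2 h and 24 h; on this read-out higher numbers stand for weaker inhibition and lower numbers for stronger inhibition:
compound 1 `COc1ccc([C@@H]2C/C(=N\O)c3c(O)cc(OCc4cn(C5CCCC5)nn4)cc3O2)cc1O` gives 6880 nM
compound 2 `COc1ccc([C@@H]2CC(=O)c3c(O)cc(OCc4cn(C5CCCC5)nn4)cc3O2)cc1O` gives 10500 nM
compound 3 `COc1ccc([C@@H]2C/C(=N\O)c3c(O)cc(OCc4cn(Cc5ccccc5F)nn4)cc3O2)cc1O` gives 5710 nM

Compound 2 has the highest of the three numbers, but its gaps to compound 1 and to compound 3 both lie within the scatter, so no order among the three can be stated. Compound 4 `COc1ccc([C@@H]2CC(=O)c3c(O)cc(OCc4cn(C5CCCCC5)nn4)cc3O2)cc1O` differs from compound 2 by cyclohexyl in place of cyclopentyl on an aromatic nitrogen. Among the measured compounds shown here, the only measured step at this position is a 1.2-fold lower number from compound 1 to compound 3 (0.08 log units; within the scatter), made on the oxime core rather than the ketone core of compound 2, and it stayed within the scatter. For the measured compounds named here, no step from cyclopentyl to cyclohexyl is available. Compound 4 is therefore expected to give 9500 nM in this assay, between 4500 nM and 20000 nM. This estimate means a step of a 1.1-fold lower number from compound 2 to compound 4 (0.04 log units; within the scatter), not beyond the scatter.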

Compound 4, half-maximal inhibitory concentration: 15600 nM
Estimate against measurement, compound 4: 1.6-fold (0.22 log units) below; the measured number falls inside the stated range.
By their numbers in this assay, from the lowest: compounds 3, 1, 2 and 4 (each within the scatter of the next, the first and the last beyond it).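

In this assay, cyclohexyl in place of cyclopentyl on the aromatic nitrogen of the core of compound 2 gives a 1.5-fold higher number from compound 2 to compound 4 (0.17 log units; within the scatter). This position has now been changed on two cores, and the earlier step, a 1.2-fold lower number from compound 1 to compound 3 (0.08 log units; within the scatter), also stays within the scatter. No evidence is available to explain these readings.

On these data alone, it remains open whether an amine or a carboxylic acid on this nitrogen would give a step beyond the scatter. As far as these compounds go, it also remains open how 2-fluorobenzyl reads on the core of compound 2.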